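Swapping Cyano for Methyl on a Benzoyl Anilide

The compounds below may be only part of what the source reports. "The series", "measured", "known", "first", "only" and "open" are said of these compounds alone.

Of the compounds shown here, three have so far been measured in a functional assay (Cavia porcellus) with sulfonylurea receptors; K-ATP channels (Homo sapiens) as the target; a higher number here means a weaker inhibitor, a lower number a stronger inhibitor. Compound 1 `CC(O)(C(=O)Nc1ccc(S(=O)(=O)c2ccccc2)c(F)c1)C(F)(F)F` gives 1800 nM, compound 2 `CC(O)(C(=O)Nc1ccc(S(=O)(=O)c2ccc(F)cc2)cc1)C(F)(F)F` gives 8600 nM, and compound 3 `CC(O)(C(=O)Nc1ccc(C(=O)c2ccccc2)cc1C#N)C(F)(F)F` gives 3800 nM. Compound 3 thus stands second highest of the three numbers: it lies beyond the scatter above compound 1 and beyond the scatter below compound 2. Compound 4 `Cc1cc(C(=O)c2ccccc2)ccc1NC(=O)C(C)(O)C(F)(F)F` differs from compound 3 in one place: methyl in place of cyano on an aromatic carbon. Among the compounds with values here, no measured pair shows this change, so the data give no direct guide to its effect. The expectation for compound 4 is a step of a 1.1-fold higher number from compound 3 to compound 4 (0.02 log units; within the scatter), that is, no change beyond the scatter. Compound 4 is therefore estimated to give 4000 nM in this assay, with a range from 1500 nM to 11000 nM.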

Compound 4, half-maximal inhibitory concentration: 5000 nM
Estimate against measurement, compound 4: 1.3-fold (0.10 log units) below, and the stated range covers the measured number.
By their numbers in this assay, from the lowest: compound 1; then compounds 3, 4 and 2 (each within the scatter of the next, the first and the last beyond it).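

In this assay, within the data shown here, methyl in place of cyano on this aromatic carbon gives a 1.3-fold higher number from compound 3 to compound 4 (0.12 log units; within the scatter), the first single-place step in this set. The swap removes a triple bond and a hydrogen-bond acceptor, yet the two numbers stay within the scatter of each other, so these two groups cannot be told apart at this position. No measurement at hand explains this result. Still open, as far as these compounds go, is how an amine, a carboxylic acid or a methoxy group would behave on this carbon. Also open, from the compounds shown here alone, is whether this swap would give a similar step on the core of compound 1 .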